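The source may hold more compounds than are shown below. What is called first, only, known or untested is meant among the compounds shown, and "the series" means these compounds.

Measured compounds:
compound 1, `CC(=N)NCCC(=O)c1ccccc1N`: > 1000000 nM
compound 2, `CC(=N)NCCC(=O)c1cc(Cl)ccc1N`: 25600 nM
compound 3, `COc1ccc(N)c(C(=O)CCNC(C)=N)c1`: 59700 nM

Of the compounds shown here, three sharing one core have been tested in an assay for inhibition of Nitric oxide synthase, inducible (Homo sapiens), read by ELISA, with a stated time of 30 min; on this read-out higher numbers stand for weaker inhibition and lower numbers for stronger inhibition. Compound 1 gives > 1000000 nM, which is the limit of > 1000000 nM in this assay, at which 1 of the 3 values shown sits, and not a number. Compound 2 gives 25600 nM in this assay, and compound 3 gives 59700 nM. Compound 3 thus holds the highest of the two numbers available; its nearest neighbour is compound 2, and the step of a 2.3-fold higher number from compound 2 to compound 3 (0.37 log units; beyond the scatter) separates the two. The other measured steps, an at least 39-fold lower number from compound 1 to compound 2 (1.59 log units; beyond the scatter) and an at least 16-fold lower number from compound 1 to compound 3 (1.22 log units; beyond the scatter), show that placing a group on the aromatic ring of the shared core moves the read-out a long way.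

Compound 4, `COc1ccc(N)c(C(=O)CCNC(=N)c2ccccc2)c1`, has not yet been measured. It differs from compound 3 in one place: phenyl in place of methyl on a carbon with a double bond to nitrogen. Within the data shown here, none of the measured steps touches this part of the molecule; all three exchange a group on an aromatic carbon, so they give no direct guide to the size or direction of this change. In the absence of such guidance, the expectation for compound 4 is a step of a 2.5-fold higher number from compound 3 to compound 4 (0.40 log units; beyond the scatter), toward a higher number, with wide uncertainty. Compound 4 is therefore estimated at 150000 nM, within a range from 30000 nM to 800000 nM.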

Compound 4, half-maximal inhibitory concentration: 45200 nM
Estimate against measurement, compound 4: 3.3-fold (0.52 log units) above; the measured number falls inside the stated range.
By their numbers in this assay, from the lowest: compounds 2, 4 and 3 (each within the scatter of the next, the first and the last beyond it). At a limit, above all of these: compound 1.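

The step of a 1.3-fold lower number from compound 3 to compound 4 (0.12 log units; within the scatter) places the two compounds within the usual scatter of each other in this assay, even though a methyl of 1 heavy atom has given way to a phenyl of 6 heavy atoms on the carbon with a double bond to nitrogen. Among these compounds, this is the first view of that part of the molecule, and it differs from the earlier steps, which all exchanged a group on an aromatic carbon and all lay beyond the scatter. In this pair, then, adding a whole aromatic ring at this place leaves the read-out indistinguishable, but nothing shown here offers a measured reason for that.

Methyl and phenyl are the only two groups seen at this place, so it remains open how the read-out would respond to an amine, a longer chain such as propyl, or a phenyl ring carrying a chloro group. The phenyl is also seen only alongside the methoxy group of compound 3, so the compounds shown do not tell whether it would behave the same way on the chloro-bearing ring of compound 2.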